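Chloro to phenethyl on the shared core: an estimate

A few compounds are considered here, and "the series" means these few. Any claim that something is new, unique, unknown or untested is made for them only; others in the source may bear on it.

Compound 1 `Cc1ccc(Cc2nc(N)c3nn(-c4ccccc4)cc3n2)cc1`: 38%
Compound 2 `Nc1nc(Cc2ccc(Cl)cc2)nc2cn(-c3ccccc3)nc12`: 49%

Of the compounds shown here, two have been measured in an assay on CHO cells for displacement of a labelled ligand from adenosine receptor A1 (Homo sapiens), read by scintillation counting, tested at 1 uM; a higher number here means more inhibition at the concentration tested (going by the name of the read-out), a lower number less inhibition. Going by the values given here, compound 1 gives 38% and compound 2 gives 49%, so compound 2 stands highest of the two, the single step between them being a number 11 percentage points higher from compound 1 to compound 2 (beyond the scatter).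

The unmeasured compound 3 `Nc1nc(CCc2ccccc2)nc2cn(-c3ccccc3)nc12` differs from compound 2 by benzyl in place of 4-chlorophenyl on a saturated chain carbon bound to an aromatic carbon. Among the compounds with values here, the one measured step bears on it only in part: it shows what chloro against methyl did on the same aromatic carbon, while nothing measured covers lengthening the chain by one carbon. With the chlorine gone, the author expects the number to fall back toward the level of compound 1 or somewhat lower, a step of about a number 14 percentage points lower from compound 2 to compound 3 (beyond the scatter) in this assay. Compound 3 is therefore estimated at 35%, within 18% to 52%.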

Compound 3, a percentage reported as inhibition, at one concentration (the size of the read-out at that concentration, not a potency): 15%
For compound 3 the middle estimate is 20 percentage points above the measured one; the measured number lies below the stated range.
By their numbers in this assay, from the lowest: compound 3; then compound 1; then compound 2.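

Read in this assay the change from 4-chlorobenzyl to phenethyl is the largest seen so far at this position, with a number 34 percentage points lower from compound 2 to compound 3 (beyond the scatter) and so a far bigger shift than the earlier swap of chloro for methyl. The comparison with the methyl-bearing compound points the same way, giving a number 23 percentage points lower from compound 1 to compound 3 (beyond the scatter) and placing the phenethyl compound below both compounds that carry a substituent on the ring. Nothing available here accounts for this fall.

As far as these compounds go, the change removes the ring substituent and lengthens the chain in one step, so the share of each in the loss stays open; a plain benzyl group or a 4-chlorophenethyl group at this place would separate the two. From the compounds shown here alone, how a longer chain such as 3-phenylpropyl would read in this assay also remains unknown.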